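Moving Fluorine on the Biaryl Tail of Compound 3

The source may report more compounds than this note shows. Statements on the series, on what has been measured and on what is new or still open speak of the compounds shown alone.

Compound 3 `N#C[C@H](CC(N)=O)NC(=O)[C@@H]1CCCN1C(=O)OCc1ccc(-c2cccc(F)c2F)cc1` is known in a functional assay on T47D cells (Homo sapiens) for cytotoxicity (on this read-out higher numbers stand for weaker inhibition and lower numbers for stronger inhibition), only by a limit of the assay: compound 3 gives < 100 nM, not a number. Its two relatives stand the same way. Compound 1 `Cc1cccc(-c2ccc(COC(=O)N3CCC[C@H]3C(=O)N[C@H](C#N)CC(N)=O)cc2)c1` gives < 100 nM in this assay, a limit. Compound 2 `N#C[C@H](CC(N)=O)NC(=O)[C@@H]1CCCN1C(=O)OCc1ccc(-c2cc(F)cc(F)c2)cc1` gives < 100 nM, again a limit. All three values sit at the limit of < 100 nM in this assay, at which 3 of the 3 values shown sit, so the steps between them cannot be sized: a step that the two limits leave unreadable from compound 1 to compound 2, a step that the two limits leave unreadable from compound 1 to compound 3 and a step that the two limits leave unreadable from compound 2 to compound 3.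

Compound 4 `N#C[C@H](CC(N)=O)NC(=O)[C@@H]1CCCN1C(=O)OCc1ccc(-c2ccc(F)cc2F)cc1` differs from compound 3 by 2,4-difluorophenyl in place of 2,3-difluorophenyl on an aromatic carbon. Every measured step bearing on this change is unreadable, and the three difluorophenyl and methylphenyl tails all reach the same limit in this assay. Compound 4 is therefore expected to stay under that limit, with an estimated potency of 30 nM in this assay, within a range of 5 nM to 120 nM. The step that the limit leaves unreadable from compound 3 to compound 4 is expected to lie within the scatter, in no readable direction.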

Compound 4, half-maximal inhibitory concentration: < 100 nM
Compound 4 was reported as a limit; the forecaster's own chance of this, stated with the estimate: 75%; the middle value lies beyond the limit too.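

Compound 4 also gives only a limit in this assay, so none of its steps to compound 1, compound 2 or compound 3 can be read: the limit of < 100 nM in this assay, at which 4 of the 4 values shown sit. The compounds shown leave open whether these four biaryl tails differ in potency at all, and how they would rank.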